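The source may hold more compounds than are shown below. What is called first, only, known or untested is meant among the compounds shown, and "the series" means these compounds.

Compound 1 `COc1cc2cc(Oc3ccc(NC(=O)Nc4cccc(C(F)(F)F)c4)cc3)c(C)nc2cc1OC` and compound 2 `COc1cc2cc(Oc3ccc(NC(=O)Nc4ccc(Cl)c(C(F)(F)F)c4)cc3)c(C)nc2cc1OC` share one core and differ in a single substituent on the aryl urea. In a functional assay on OVCAR-5 cells (Homo sapiens) for inhibition, read by sulforhodamine B assay, with a stated time of 48 h (a higher number here means a weaker inhibitor of growth, a lower number a stronger inhibitor of growth), compound 1 gives 3020 nM, and in this assay compound 2 gives 1930 nM. On the numbers shown compound 2 carries the lower figure of the two, but the gap from compound 1, a 1.6-fold lower number from compound 1 to compound 2 (0.19 log units; within the scatter), is within the scatter, so no order between them is established.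

Compound 3 `COc1cc2cc(Oc3ccc(NC(=O)Nc4ccc(Cl)c(Cl)c4)cc3)c(C)nc2cc1OC` follows from compound 2 by chloro in place of trifluoromethyl on an aromatic carbon. Within the data shown here, no measured step exchanges a trifluoromethyl for a chloro, so the only step that bears on it is a 1.6-fold lower number from compound 1 to compound 2 (0.19 log units; within the scatter), which shows that a single substituent change on this ring of the urea left the number inside the scatter. The step expected from compound 2 to compound 3 in this assay is accordingly a 1.3-fold higher number from compound 2 to compound 3 (0.11 log units; within the scatter), with no direction that goes beyond the scatter. For compound 3 in this assay the estimated value is 2500 nM, expected to fall between 1000 nM and 6500 nM.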

Compound 3, concentration for 50% growth inhibition: 10100 nM
Estimate against measurement, compound 3: 4.0-fold (0.61 log units) below; measured number above the stated range.
By their numbers in this assay, from the lowest: compounds 2 and 1 (each within the scatter of the next); then compound 3.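

In this assay the place ortho to a chloro group on the aryl urea proves sensitive to what sits there: trifluoromethyl and chloro are not interchangeable, with a 5.2-fold higher number from compound 2 to compound 3 (0.72 log units; beyond the scatter), whereas the earlier single change on this ring stayed within the scatter. Exchanging the whole aryl group points the same way, with a 3.3-fold higher number from compound 1 to compound 3 (0.52 log units; beyond the scatter), so compound 3, the only one of the three without a trifluoromethyl group, carries the highest number, with its steps to both other compounds beyond the scatter. No measurement shown here accounts for this difference.

The compounds shown hold only trifluoromethyl and chloro at this place, so it remains open where a nitrile, a methoxy group or a plain methyl group would fall relative to them, and so whether the result is particular to trifluoromethyl. Also open, as far as these compounds go, is whether the gap between trifluoromethyl and chloro persists without the chloro group that compound 2 and compound 3 share, or with an amine in its stead.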